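From compound 2 to compound 3: losing the hydroxy

The source may hold more compounds than are shown below. What is called first, only, known or untested is meant among the compounds shown, and "the series" means these compounds.

In a functional assay on U-251 cells (Homo sapiens) (on this read-out higher numbers stand for weaker inhibition of growth and lower numbers for stronger inhibition of growth), compound 2 `O=S(=O)(/C=C/c1ccc(O)cc1)Cc1ccc(Nc2ncnc3ccc(Br)cc23)cc1` gives > 100000 nM, which is a limit and not a number. Compound 1 `O=S(=O)(/C=C/c1ccc(Cl)cc1)Cc1ccc(Nc2ncnc3ccc(Br)cc23)cc1` gives 30000 nM. Compound 3 `O=S(=O)(/C=C/c1ccc(C(F)(F)F)cc1F)Cc1ccc(Nc2ncnc3ccc(Br)cc23)cc1` has 2-fluoro-4-(trifluoromethyl)phenyl in place of 4-hydroxyphenyl on a double-bonded chain carbon bound to a double-bonded chain carbon. Among the compounds with values here, the only measured step bearing on this is an at least 3.3-fold higher number from compound 1 to compound 2 (0.52 log units; beyond the scatter), a change of at least modest size on introducing hydroxy in place of chloro. Losing the hydroxy should therefore reverse that step, and a modest fall in this assay is expected: an at least 3.3-fold lower number from compound 2 to compound 3 (0.52 log units; beyond the scatter). For compound 3 the estimated value is 30000 nM, with an expected range of 8000 nM to 100000 nM.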

Compound 3, concentration for 50% growth inhibition: 30000 nM
Estimate against measurement, compound 3: no gap at the digits printed; the range from low to high includes it.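

In this assay, 2-fluoro-4-(trifluoromethyl)phenyl in place of 4-hydroxyphenyl gives an at least 3.3-fold lower number from compound 2 to compound 3 (0.52 log units; beyond the scatter). Compound 2 carries a limit and not a number, so the size of this step is only a bound: the limit of > 100000 nM in this assay, at which 1 of the 3 values shown sits.

Against 4-chlorophenyl, the same group gives no change at the digits printed from compound 1 to compound 3 (within the scatter), so two different groups without the hydroxy read alike at this position, and compound 2 alone stands apart.

From the compounds shown here alone, the separate shares of the fluoro and the trifluoromethyl in compound 3 stay open. Also open, going by these compounds, is whether the weak reading of compound 2 is specific to hydroxy, which a methoxy or an amine in its place would test.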